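A few compounds are considered here, and "the series" means these few. Any claim that something is new, unique, unknown or untested is made for them only; others in the source may bear on it.

Measured so far:
compound 1, `COc1cc(N/C=C\C(=O)c2cn(-c3ccccc3)nc2-c2ccccc2)cc(OC)c1OC` — 5930 nM
compound 2, `COc1ccc(-c2nn(-c3ccccc3)cc2C(=O)/C=C\Nc2ccc(Cl)cc2)cc1` — 3890 nM

Of the compounds shown here, two have been tested in a functional assay on PC-3 cells (Homo sapiens) for antiproliferative activity, read by MTT assay, with a stated time of 48 h; on this read-out lower numbers stand for stronger inhibition and higher numbers for weaker inhibition. Compound 1, `COc1cc(N/C=C\C(=O)c2cn(-c3ccccc3)nc2-c2ccccc2)cc(OC)c1OC`, gives 5930 nM in this assay. Compound 2, `COc1ccc(-c2nn(-c3ccccc3)cc2C(=O)/C=C\Nc2ccc(Cl)cc2)cc1`, gives 3890 nM. Compound 2 yields the lower of the two numbers, yet the gap to compound 1 lies within the usual scatter of repeated measurements, so the two cannot be told apart on these data.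

The next compound, compound 3, `COc1ccc(-c2nn(-c3ccccc3)cc2C(=O)/C=C\Nc2cc(OC)c(OC)c(OC)c2)cc1`, follows from compound 2 by one change: 3,4,5-trimethoxyphenyl in place of 4-chlorophenyl on an amine nitrogen. Going by the values given here, no step between measured compounds is available to guide this change; compound 1 already carries the 3,4,5-trimethoxyphenyl group on its amine nitrogen and its number sits close to that of compound 2. The step from compound 2 to compound 3 is therefore expected to be small, a 1.3-fold higher number from compound 2 to compound 3 (0.11 log units; within the scatter), not clearly beyond the scatter in either direction. Compound 3 is estimated at 5000 nM, with a range from 2000 nM to 14000 nM.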

Compound 3, half-maximal inhibitory concentration: 18900 nM
The estimate for compound 3 lay 3.8-fold (0.58 log units) below the measured number; measured number outside the range, above it.
By their numbers in this assay, from the lowest: compounds 2 and 1 (each within the scatter of the next); then compound 3.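

In this assay, placing 3,4,5-trimethoxyphenyl instead of 4-chlorophenyl on the amine nitrogen gives a 4.9-fold higher number from compound 2 to compound 3 (0.69 log units; beyond the scatter), the first clear sign that inhibition responds to the group at this position. A second place on the molecule also matters: with 3,4,5-trimethoxyphenyl on the amine nitrogen in both compounds, methoxy in place of hydrogen on an aromatic carbon gives a 3.2-fold higher number from compound 1 to compound 3 (0.50 log units; beyond the scatter). Both steps point towards weaker inhibition, and nothing here gives a measured reason for either one.

Going by these compounds, whether that methoxy has the same effect when 4-chlorophenyl sits on the amine nitrogen remains open. So does how a plain phenyl or a cyclohexyl group would compare at that nitrogen.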